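Halogen swap on the pyrazole of compound 3

The compounds below may be only part of what the source reports. "The series", "measured", "known", "first", "only" and "open" are said of these compounds alone.

Among the measured compounds shown here, compound 3 `CCn1cc(NC(=O)c2ccc(Cn3nc(C)c(Br)c3C)o2)c(C(N)=O)n1` carries the only number in the set: in a functional assay on HT-1080 cells (Homo sapiens) for inhibition, read by WST assay and cell counting, with a stated time of 72 h (on this read-out lower numbers stand for stronger inhibition and higher numbers for weaker inhibition), compound 3 gives 7000 nM. Compound 1 `CCn1cc(NC(=O)c2ccc(Cc3c(C)noc3C)o2)c(C(N)=O)n1` reaches only a limit of this assay, > 100000 nM. Compound 2 `CCn1ncc(NC(=O)c2ccc(Cn3nc(C)cc3C)o2)c1C(N)=O` likewise sits at a limit, > 100000 nM. For the measured compounds named here, two of the three values therefore rest at the limit of > 100000 nM in this assay, at which 2 of the 3 values shown sit, and the single measured step, an at least 14-fold lower number from compound 1 to compound 3 (1.15 log units; beyond the scatter), exchanges the whole heterocycle rather than a substituent on it.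

Compound 4 `CCn1cc(NC(=O)c2ccc(Cn3nc(C)c(Cl)c3C)o2)c(C(N)=O)n1` differs from compound 3 by chloro in place of bromo on an aromatic carbon. Going by the values given here, no measured step touches only the halogen on the pyrazole, so the step from compound 1 to compound 3 bears on it only loosely: it shows that this ring, with a halogen in place, is what carries compound 3 off the limit. A change confined to the halogen is expected to move the number little, so for compound 4 the step of a 1.4-fold higher number from compound 3 to compound 4 (0.15 log units; within the scatter) is expected to stay within the scatter or slightly weaken. Compound 4 is expected to give about 10000 nM in this assay, within 3500 nM to 30000 nM.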

Compound 4, half-maximal inhibitory concentration: 7400 nM
Compound 4: the middle estimate sits 1.4-fold (0.13 log units) above what was measured; measured number inside the range.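

Chloro and bromo on this aromatic carbon cannot be told apart in this assay: a 1.1-fold higher number from compound 3 to compound 4 (0.02 log units; within the scatter). The result of the earlier exchange of the whole heterocycle is therefore not tied to bromo alone, since 4-chloro-3,5-dimethyl-1H-pyrazol-1-yl in place of 3,5-dimethyl-1,2-oxazol-4-yl also gives an at least 13-fold lower number from compound 1 to compound 4 (1.13 log units; beyond the scatter). The size of that step stays open-ended, as compound 1 gives a limit of the assay and not a number: the limit of > 100000 nM in this assay, at which 2 of the 4 values shown sit.

As far as these compounds go, whether a halogen is needed on this carbon at all remains open, as does what fluoro, iodo, a nitrile or a methoxy group would give there. From the compounds shown here alone, the methyl groups on the two neighbouring ring atoms also remain untested, for example against ethyl or hydrogen.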